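The source may report more compounds than this note shows. Statements on the series, on what has been measured and on what is new or still open speak of the compounds shown alone.

Measured in a physicochemical assay for lipophilicity; on this read-out lower numbers stand for lower lipophilicity and higher numbers for higher lipophilicity:
- compound 1 `CCCCCCN(CCCCCSc1nc2ccc[nH]c-2n1)C(=O)Nc1ccc(F)cc1F`: 6.22
- compound 2 `CCCCCCCN(CCCCCSc1nc(N)c2c[nH]nc2n1)C(=O)Nc1ccc(F)cc1F`: 5.74
- compound 3 `CCCCCCCN(CCCCCSc1nc(N)c2c[nH]nc2n1)C(=O)NC(C)C`: 5.14

Compound 3 is the lowest of the three. Within the data shown here, the only single-place comparison is a number 0.60 log units lower from compound 2 to compound 3 (beyond the scatter), a modest step beyond the scatter, with isopropyl in place of 2,4-difluorophenyl on an amide-type nitrogen.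

The next compound is compound 4 `CCCCCCCN(CCCCCSc1[nH]cnc2ncnc1-2)C(=O)NC(C)C`. Its change is a group of 9 heavy atoms (5 carbon, 4 nitrogen; one five-membered aromatic ring with 2 hetero atoms, one six-membered aromatic ring with 2 hetero atoms) in place of a group of 10 heavy atoms (5 carbon, 5 nitrogen; one five-membered aromatic ring with 2 hetero atoms, one six-membered aromatic ring with 2 hetero atoms), on a sulfur, and it sits on a sulfur whose other neighbours are: saturated chain carbon. The measured step from compound 2 lies at another place, so it does not describe this change and serves only as a guide to how large a single change can be in this assay.

Compound 1 also carries a different group on the sulfur, but it differs from compound 2 in more than one place. Compound 1 gives 6.22 against 5.74 for compound 2, and this gap is the only hint of direction, so it is weak evidence. A rise smaller than the measured step is therefore expected, and the estimated change is a number 0.36 log units higher from compound 3 to compound 4 (beyond the scatter). Compound 4 is estimated at 5.5, with an expected range of 5 to 6.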

Compound 4, partition coefficient: 4.72
Beside the measured number, compound 4's estimate is 0.78 log units above it; measured number outside the range, below it.
By their numbers in this assay, from the lowest: compound 4; then compound 3; then compound 2; then compound 1.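

In this assay, the group on the sulfur proves to be a place where a single change moves the read-out, with a number 0.42 log units lower from compound 3 to compound 4 (beyond the scatter) as the first step measured there. Among these compounds, the only earlier single-place step lay on the amide-type nitrogen, where isopropyl replacing 2,4-difluorophenyl gave a number 0.60 log units lower from compound 2 to compound 3 (beyond the scatter) and was also modest, so both places can now shift the number beyond the scatter. The group that enters has 9 heavy atoms, 1 hydrogen-bond donor and 3 hydrogen-bond acceptors against 10 heavy atoms, 2 hydrogen-bond donors and 4 hydrogen-bond acceptors in the group that leaves, but no measurement at hand links the lower number to any one of these differences.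

It remains open whether the same exchange on the sulfur gives a step of similar size and direction with 2,4-difluorophenyl on the amide-type nitrogen, as the entering group is shown only with isopropyl. Also open, from the compounds shown here alone, is how the number moves when the group on the sulfur carries a carboxylic acid or a dimethylamino group.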